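The compounds below may be only part of what the source reports. "The series", "measured", "known", "first", "only" and "open" are said of these compounds alone.

Measured so far, in a functional assay on DU-145 cells (Homo sapiens) for inhibition, read by WST assay, with a stated time of 3 days; a higher number here means a weaker inhibitor, a lower number a stronger inhibitor:

Compound 1, `Cn1ccnc1/C=C/C(=O)/C=C/c1coc2ccccc2c1=O`: 4500 nM
Compound 2, `CCCCCn1ccnc1/C=C/C(=O)/C=C/c1coc2ccccc2c1=O`: 2700 nM

Compound 1 gives the highest of the two numbers; its nearest neighbour is compound 2, reached by a 1.7-fold lower number from compound 1 to compound 2 (0.22 log units; within the scatter), a step that stays within the scatter of the assay.

The next compound, compound 3, has the structure `CC(C)CCn1ccnc1/C=C/C(=O)/C=C/c1coc2ccccc2c1=O`. It differs from compound 1 in one place: isobutyl in place of hydrogen on a saturated chain carbon bound to an aromatic nitrogen. Among the compounds with values here, only one measured step bears on this change, the one from compound 1 to compound 2, where butyl took the place of hydrogen on the same saturated chain carbon bound to an aromatic nitrogen; that step was a 1.7-fold lower number from compound 1 to compound 2 (0.22 log units; within the scatter) and did not rise above the scatter. Isobutyl is a branched relative of butyl, so compound 3 is expected to behave much like compound 2, with a step of about a 1.5-fold lower number from compound 1 to compound 3 (0.18 log units; within the scatter), likely no more than the scatter and, if anything, toward a slightly lower number. For compound 3 the expected value in this assay is 3000 nM, with a range from 1500 nM to 6000 nM.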

Compound 3, half-maximal inhibitory concentration: 5800 nM
Compound 3: the middle estimate sits 1.9-fold (0.29 log units) below what was measured, and the stated range covers the measured number.
By their numbers in this assay, from the lowest: compounds 2, 1 and 3 (each within the scatter of the next, the first and the last beyond it).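

In this assay, within the data shown here, isobutyl in place of hydrogen on a saturated chain carbon bound to an aromatic nitrogen gives a 1.3-fold higher number from compound 1 to compound 3 (0.11 log units; within the scatter), so this group, like the one in compound 2, does not separate from the methyl compound beyond the usual scatter. What compound 3 adds is that the shape of the chain can register here: isopropyl in place of propyl on a saturated chain carbon, two bonds along the chain from an aromatic nitrogen, gives a 2.1-fold higher number from compound 2 to compound 3 (0.33 log units; beyond the scatter), a modest step and the only one so far beyond the scatter. That reading rests on a single pair, and compound 1 lies within the scatter of both compound 2 and compound 3, so it marks a small difference between two chains and not a general rule about branching.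

No measurement offered here accounts for the gap between these two chains. The compounds shown leave open whether a longer chain, a chain ending in an amine or a carboxylic acid, or a cyclohexyl group at this position would move the number clearly beyond the scatter in either direction.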